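Selenocyanate carbamates: effect of dropping the methoxy

This account rests on a few compounds, and the source may have more. Where it says the series, first, only, none or still open, it means among the compounds named here.

Measured compounds:
compound 1 `COc1ccc(OC(=O)Nc2ccc([Se]C#N)cc2)cc1`, in a functional assay on HTB-54 cells (Homo sapiens) for cytotoxicity, read by MTT assay, with a stated time of 72 h (a lower number here means a stronger inhibitor of growth, a higher number a weaker inhibitor of growth), compound 1 gives 23700 nM
compound 2 `O=C(Nc1ccc([Se][Se]c2ccc(NC(=O)OCc3ccc([N+](=O)[O-])cc3)cc2)cc1)OCc1ccc([N+](=O)[O-])cc1`, in this assay compound 2 gives 31800 nM

Among the compounds with values here, compound 1 has the lowest of the two numbers in this assay, but the only other number, that of compound 2, lies within the scatter of it, so the two compounds cannot be ordered against each other. Compound 2 differs from compound 1 in several places at once, so its number says nothing about any single group.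

Compound 3 `N#C[Se]c1ccc(NC(=O)Oc2ccccc2)cc1` is not yet measured in this assay. It differs from compound 1 in one place: hydrogen in place of methoxy on an aromatic carbon. Within the data shown here, no pair of measured compounds differs in one place, so there is no measured step to guide this one. A single small group leaving an aromatic carbon, with nothing else changed, is expected to move the number in this assay no further than the scatter, in no preferred direction, giving a step of a 1.1-fold higher number from compound 1 to compound 3 (0.02 log units; within the scatter) that is expected to be small. Compound 3 is therefore estimated at 25000 nM in this assay, with a range from 9000 nM to 65000 nM.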

Compound 3, concentration for 50% growth inhibition: 26200 nM
Compound 3: middle estimate off by 1.0-fold (0.02 log units), on the low side; low and high end bracket the measured number.
By their numbers in this assay, from the lowest: compounds 1, 3 and 2 (each within the scatter of the next).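

In this assay, hydrogen in place of methoxy on an aromatic carbon, para to a large group, gives a 1.1-fold higher number from compound 1 to compound 3 (0.04 log units; within the scatter), the only step among the compounds shown that reads a single place. At this position, then, methoxy and hydrogen cannot be told apart in this assay, so the methoxy is not required for a number of this size, and the removal of this group neither gains nor loses anything that can be read beyond the scatter. No measured property of either group is available to bear on this result.

Still open, on these data alone, is whether this position is insensitive to substitution in general or only to this one exchange, since an amine, a carboxylic acid or a longer chain such as ethoxy on the same aromatic carbon could still move the number beyond the scatter. Also open, as far as these compounds go, is the part played by the selenocyanate group itself, since compound 2 differs from the other two compounds in several places at once and so cannot isolate it, and a single-place change at that group, such as a thiocyanate in its stead, would be needed to read it.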